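The compounds below may be only part of what the source reports. "The series", "measured", "known", "first", "only" and "open" are said of these compounds alone.

Compound 1, `CC(C)(C)Cc1c(-c2ccncc2)sc(N)c1C(=O)c1ccc(Cl)cc1`: 6%
Compound 2, `CC(C)(C)Cc1c(-c2ccccn2)sc(N)c1C(=O)c1ccc(Cl)cc1`: 1%

In an assay on CHO cells for displacement of a labelled ligand from adenosine receptor A3 (Homo sapiens), read by scintillation counting, tested at 10 uM (a higher number here means more inhibition at the concentration tested (going by the name of the read-out), a lower number less inhibition), compound 2 stands lowest of the two numbers, with compound 1 nearest; that step was a number 5 percentage points lower from compound 1 to compound 2 (within the scatter). Compound 3, `CC(C)(C)Cc1c(-c2ccc(F)cc2)sc(N)c1C(=O)c1ccc(Cl)cc1`, is not yet measured and differs from compound 2 by 4-fluorophenyl in place of pyridin-2-yl on an aromatic carbon. Among the measured compounds shown here, the only measured step, a number 5 percentage points lower from compound 1 to compound 2 (within the scatter), also exchanged the aromatic ring at this place and stayed within the scatter, so for compound 3 no step beyond the scatter is expected in this assay either. Compound 3 is estimated at 4%, range -10% to 20%. The expected step is a number 3 percentage points higher from compound 2 to compound 3 (within the scatter).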

Compound 3, a percentage reported as inhibition, at one concentration (the size of the read-out at that concentration, not a potency): 9%
For compound 3 the middle estimate is 5 percentage points below the measured one, within the range that was stated.
By their numbers in this assay, from the lowest: compounds 2, 1 and 3 (each within the scatter of the next).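

In this assay, 4-fluorophenyl in place of pyridin-2-yl gives a number 8 percentage points higher from compound 2 to compound 3 (within the scatter), and in place of pyridin-4-yl it gives a number 3 percentage points higher from compound 1 to compound 3 (within the scatter). At this place next to the ring sulfur, then, a ring of carbon only, without the ring nitrogen of either pyridine, stays within the scatter of both, which the step between the two pyridines alone could not show. No measurement given here offers an explanation for these numbers. On these data alone, whether a carboxylic acid or an aliphatic amine at this place would move the number beyond the scatter remains open.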